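Series notes: capping the phenolic oxygen of compound 2

This account rests on a few compounds, and the source may have more. Where it says the series, first, only, none or still open, it means among the compounds named here.

compound 1 `Cc1ccc(O)c(/C=N\NC(=O)c2oc3cccc(O)c3c2C)c1`: 7350 nM in a functional assay on PC-3 cells (Homo sapiens) for inhibition; on this read-out higher numbers stand for weaker inhibition and lower numbers for stronger inhibition
compound 2 `Cc1c(C(=O)N/N=C\c2cccc(O)c2)oc2cccc(O)c12`: 17600 nM in this assay

Going by the values given here, compound 2 stands at the highest of the two numbers so far in this assay; its only neighbour is compound 1, and the single measured step, a 2.4-fold higher number from compound 1 to compound 2 (0.38 log units; beyond the scatter), replaces 2-hydroxy-5-methylphenyl with 3-hydroxyphenyl on a carbon with a double bond to nitrogen.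

Compound 3 `COc1cccc(/C=N\NC(=O)c2oc3cccc(O)c3c2C)c1` differs from compound 2 by methyl in place of hydrogen on an oxygen on an aromatic ring, hydroxy to methoxy, 3-hydroxyphenyl to 3-methoxyphenyl. Among the compounds with values here, no measured step touches this oxygen, so the one step seen gives only the scale of change and no direction for this change. The working expectation is therefore no step beyond the scatter. Compound 3 is estimated at 20000 nM, with a range of 6000 nM to 60000 nM. That estimate corresponds to a 1.1-fold higher number from compound 2 to compound 3 (0.06 log units; within the scatter), which is expected to lie within the scatter.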

Compound 3, half-maximal inhibitory concentration: >= 40000 nM
Compound 3: only a limit was reported (the forecaster's own chance of this, stated with the estimate: 20%); middle value at least 2.0-fold (0.30 log units) from the limit.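

Compound 3 is reported in this assay only as a limit, >= 40000 nM. Methyl on this oxygen, hydroxy to methoxy on the ring, gives an at least 2.2-fold higher number from compound 2 to compound 3 (0.35 log units; beyond the scatter), so the step is beyond the scatter towards weaker inhibition, which the earlier compounds could not show, and its full size remains unknown. Taken from the other neighbour, the swap of 2-hydroxy-5-methylphenyl for 3-methoxyphenyl gives an at least 5.4-fold higher number from compound 1 to compound 3 (0.73 log units; beyond the scatter), so the free hydroxy on this ring is favoured over methoxy in both comparisons.

The compounds shown leave open whether the change follows from methyl alone or from any capping of this oxygen, since a longer chain such as ethoxy, or an acetyl group, has no value here. On these data alone, it is also open whether an amine in place of the hydroxy would keep the value of compound 2, 17600 nM.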